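The source may hold more compounds than are shown below. What is called first, only, known or untested is meant among the compounds shown, and "the series" means these compounds.

Measured compounds:
compound 1 `O=C1OCCN1C(=O)c1ccc(Oc2ccc(O)cc2)cc1` — in an assay on HEK293 cells for inhibition of N-acylethanolamine-hydrolyzing acid amidase (Rattus norvegicus), read by LC-MS, with a stated time of 30 min (on this read-out lower numbers stand for stronger inhibition and higher numbers for weaker inhibition), compound 1 gives > 20000 nM; this is a limit of the assay, not a number (the limit of > 20000 nM in this assay, at which 1 of the 3 values shown sits).
compound 2 `Cc1cccc(Oc2ccc(C(=O)N3CCOC3=O)cc2)c1` — compound 2 gives 5210 nM in this assay.
compound 3 `Cc1ccc(Oc2ccc(C(=O)N3CCOC3=O)cc2)cc1` — compound 3 gives 6400 nM in this assay.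

Compound 3 holds the highest of the two numbers shown, but its only neighbour is close: a 1.2-fold higher number from compound 2 to compound 3 (0.09 log units; within the scatter), so compound 2 and compound 3 cannot be ordered. Against the limit of compound 1 the two methyl compounds stand apart: an at least 3.8-fold lower number from compound 1 to compound 2 (0.58 log units; beyond the scatter) and an at least 3.1-fold lower number from compound 1 to compound 3 (0.49 log units; beyond the scatter).

Compound 4 `O=C1OCCN1C(=O)c1ccc(OC2CCCCC2)cc1` is the next member. Its change: cyclohexyl in place of 4-methylphenyl on an oxygen on an aromatic ring. Among the compounds with values here, none of the measured steps trades the aromatic ring on that oxygen for a saturated ring; the steps from compound 1 only exchange a substituent on that ring, and the step from compound 2 to compound 3 only moves the methyl, with no effect beyond the scatter. The measured steps therefore give no direct guidance on the size or direction of this change in this assay; the expectation is for a step of no more than modest size, with a real chance that compound 4 returns only a limit. Compound 4 is estimated at 9000 nM, expected between 2500 nM and 30000 nM. That estimate means an expected step of a 1.4-fold higher number from compound 3 to compound 4 (0.15 log units; within the scatter).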

Compound 4, half-maximal inhibitory concentration: 92 nM
Beside the measured number, compound 4's estimate is 98-fold (1.99 log units) above it; the whole stated range lies above it.
By their numbers in this assay, from the lowest: compound 4; then compounds 2 and 3 (each within the scatter of the next). At a limit, above all of these: compound 1.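

In this assay, the group on an oxygen on an aromatic ring proves far more sensitive than the earlier exchanges showed: cyclohexyl in place of the methylphenyl groups gives a 70-fold lower number from compound 3 to compound 4 (1.84 log units; beyond the scatter) and a 57-fold lower number from compound 2 to compound 4 (1.75 log units; beyond the scatter), both large, while moving the methyl gave only a 1.2-fold higher number from compound 2 to compound 3 (0.09 log units; within the scatter). Cyclohexyl in place of 4-hydroxyphenyl gives an at least 210-fold lower number from compound 1 to compound 4 (2.33 log units; beyond the scatter), so all three aromatic groups shown on that oxygen give weaker inhibition than cyclohexyl, with no compound shown going against this, although the pattern rests on compound 4 as the only saturated member. The value of compound 1 is a limit and not a number, so its step gives only a bound: the limit of > 20000 nM in this assay, at which 1 of the 4 values shown sits.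

On these data alone, what remains open is whether the gain needs a six-membered ring at all, since a cyclopentyl group, an open hexyl chain or a plain phenyl would separate ring size, ring shape and the loss of aromaticity. Equally open, as far as these compounds go, is how much polarity the saturated ring tolerates, which a piperidine amine or a hydroxyl on the cyclohexyl ring would test, and the numbers here do not say why cyclohexyl gives the stronger inhibition.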